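Acetyl for dimethylamino on the aryl of compound 1

A few compounds are considered here, and "the series" means these few. Any claim that something is new, unique, unknown or untested is made for them only; others in the source may bear on it.

Compound 1 `COc1cc(C)cc(-c2c(-c3ccnc(-c4ccc(N(C)C)cc4)c3)cnn2CC#N)c1` is the lowest of the two compounds measured in a functional assay on NCI-H460 cells (Homo sapiens) for cytotoxicity, read by sulforhodamine B assay, with a stated time of 48 h, tested at 100 nM (a lower number here means a stronger effect, a higher number a weaker effect of the compound at the concentration tested), where compound 1 gives -43%. Compound 2 `COc1cc(C)cc(-c2nn(CC#N)cc2-c2ccc(-c3cccc(C(C)=O)c3)nc2)c1` is its nearest neighbour on this assay, and compound 2 gives 84%, a gap beyond the scatter. Compound 3 `COc1cc(C)cc(-c2c(-c3ccnc(-c4ccc(C(C)=O)cc4)c3)cnn2CC#N)c1` has not yet been measured. It differs from compound 1 by acetyl in place of dimethylamino on an aromatic carbon. Among the measured compounds shown here, as no measured pair shares this change, the step of a number 83 percentage points higher from compound 1 to compound 3 (beyond the scatter) is an expectation only, leaning to a weaker effect because compound 2 carrying an acetyl gives 84%. Compound 3 is therefore estimated at 40%, within -20% to 90%.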

Compound 3, a percentage reported as activity, at one concentration (the size of the read-out at that concentration, not a potency): 87%
For compound 3 the middle estimate is 47 percentage points below the measured one; the measured number falls inside the stated range.
By their numbers in this assay, from the lowest: compound 1; then compounds 2 and 3 (each within the scatter of the next).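

Acetyl in place of dimethylamino on an aromatic carbon gives a number 130 percentage points higher from compound 1 to compound 3 (beyond the scatter) in this assay, so this single change on the core of compound 1 is enough to remove the strong effect at the concentration tested. The two groups have the same count of heavy atoms and of hydrogen-bond acceptors, so those counts do not separate them. No measurement shown here accounts for the step.

As far as these compounds go, it remains open whether a primary amine or diethylamino at this place would keep the effect seen with dimethylamino. From the compounds shown here alone, it also remains open whether a carboxylic acid there would match acetyl.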